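This account rests on a few compounds, and the source may have more. Where it says the series, first, only, none or still open, it means among the compounds named here.

This short series asks how small changes on one side-chain oxygen affect the harm a set of related compounds does to cultured cells, as read in an ADME assay on Vero cells (Chlorocebus sabaeus) for cytotoxicity, read by neutral red uptake; a higher number here means a weaker inhibitor, a lower number a stronger inhibitor. Compound 1, `CC1=CC(=O)/C(=C(O)/C=C/c2ccc(Cl)cc2)C1=O`, is the starting point. In this assay compound 1 gives > 10 ug/mL, and this is a limit of the measurement rather than a number. Two relatives are already known. Compound 2, `CC(=O)OC(/C=C/c1ccccc1)=C1\C(=O)C=C(C)C1=O`, in this assay gives 5.5 ug/mL. Compound 3, `CO/C(=C1\C(=O)C=C(C)C1=O)c1ccccc1`, in this assay gives > 10 ug/mL, which is again a limit and not a number. So compound 1 stands where most of the series stands: the limit of > 10 ug/mL in this assay, at which 2 of the 3 values shown sit. Compound 4, `COC(/C=C/c1ccc(Cl)cc1)=C1\C(=O)C=C(C)C1=O`, is the compound yet to be measured. It differs from compound 1 by methyl in place of hydrogen on an oxygen on an unsaturated carbon. Among the measured compounds shown here, no step between two measured compounds has been worked out here, so the size of this step can only be judged from the surrounding values. Compound 3, which also carries a methyl on that oxygen, gives > 10 ug/mL, a limit, and that supports expecting compound 4 to stay close to compound 1. The expected step is therefore small, none beyond the scatter: a step that the limit leaves unreadable from compound 1 to compound 4. Compound 4 is expected to give about 12 ug/mL in this assay, most likely between 5 ug/mL and 30 ug/mL, with a real chance that only a limit is reported again.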

Compound 4, half-maximal inhibitory concentration: 5.5 ug/mL
Estimate against measurement, compound 4: 2.2-fold (0.34 log units) above, and the stated range covers the measured number.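

In this assay, compound 4 gives a real number where compound 1 gave only a limit, so replacing hydroxy with methoxy on this oxygen brings the compound into the range the read-out can measure. Set against that limit, the change gives an at least 1.8-fold lower number from compound 1 to compound 4 (0.25 log units; that floor lies within the scatter), which means the true step could be small or considerably larger, and the data so far cannot separate these cases. The value for compound 1 remains a limit and not a number, and such limits are still common in this small set: the limit of > 10 ug/mL in this assay, at which 2 of the 4 values shown sit.

As far as these compounds go, what stays open is the true distance between compound 1 and compound 4, and how the value in this assay would respond to other groups on this oxygen, such as an ethyl group, a longer chain or a chain ending in a carboxylic acid. A single pair also cannot show whether the same replacement of hydrogen by methyl would read the same way on a different side chain.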